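The source may hold more compounds than are shown below. What is called first, only, known or untested is meant among the compounds shown, and "the series" means these compounds.

Measured so far in an assay on C3H 10T1/2 cells for inhibition of Sonic hedgehog protein (Mus musculus), read by a luciferase reporter; on this read-out lower numbers stand for stronger inhibition and higher numbers for weaker inhibition:
compound 1 `Cc1nc(C(F)(F)F)ccc1C(=O)Nc1ccc(Cl)c(-c2nc3ccccc3[nH]2)c1`: 12 nM
compound 2 `Cc1ccc(C(=O)Nc2ccc(Cl)c(-c3ccccn3)c2)c(C)n1`: 130 nM
compound 3 `O=C(Nc1ccc(Cl)c(-c2ccccn2)c1)c1cccnc1`: 600 nM

Compound 3 gives the highest number of the three in this assay; compound 2 lies nearest to it and compound 1 furthest, both steps beyond the scatter. Among the measured compounds shown here, the one measured step, a 4.6-fold higher number from compound 2 to compound 3 (0.66 log units; beyond the scatter), concerns the removal of two methyl groups from the ring on the carbonyl carbon and says nothing about where the ring nitrogen sits.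

Compound 4 `O=C(Nc1ccc(Cl)c(-c2ccccn2)c1)c1ccncc1` differs from compound 3 by pyridin-4-yl in place of pyridin-3-yl on a carbonyl carbon. For the measured compounds named here, no measured pair shows this change, so no step bears on it directly; the group that leaves and the group that enters are alike in everything that is counted. With no measured guidance, the step from compound 3 to compound 4 is expected to be no change at the digits printed from compound 3 to compound 4 (within the scatter), that is, nothing beyond the scatter, and the band around the estimate is kept wide. Compound 4 is therefore estimated at 600 nM in this assay, with a range from 200 nM to 1800 nM.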

Compound 4, half-maximal inhibitory concentration: 700 nM
Estimate against measurement, compound 4: 1.2-fold (0.07 log units) below; low and high end bracket the measured number.
By their numbers in this assay, from the lowest: compound 1; then compound 2; then compounds 3 and 4 (each within the scatter of the next).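

In this assay, among the compounds shown here, the pair adds what the earlier compounds could not show: on a carbonyl carbon bearing the amide-type nitrogen, a 1.2-fold higher number from compound 3 to compound 4 (0.07 log units; within the scatter) leaves pyridin-3-yl and pyridin-4-yl indistinguishable, so the placement of the ring nitrogen between these two groups has no readable effect on this core. With a 5.4-fold higher number from compound 2 to compound 4 (0.73 log units; beyond the scatter), 2,6-dimethylpyridin-3-yl now stands apart beyond the scatter from both pyridine groups without methyl substituents, not from pyridin-3-yl alone. Nothing available explains either result.

Open, going by these compounds, is how each of the two methyl groups contributes on its own, since compound 2 carries both and neither compound 3 nor compound 4 carries either. Also open, on these data alone, is how a phenyl ring or pyridin-2-yl would compare at this carbonyl carbon.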